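A few compounds are considered here, and "the series" means these few. Any claim that something is new, unique, unknown or untested is made for them only; others in the source may bear on it.

Compound 1, `Cn1nc(Cc2nnc(SCCCCCCCC(=O)Nc3ccc(Cl)cc3Cl)n2CCCO)c2ccccc2c1=O`, and compound 2, `Cn1nc(Cc2nnc(SCCCCCCCC(=O)Nc3ccc(Cl)cc3Cl)n2CCC(=O)O)c2ccccc2c1=O`, share one core and differ in a single spot: carboxy in place of hydroxymethyl on a saturated chain carbon, two bonds along the chain from an aromatic nitrogen. In an assay on 32D cells for inhibition of interleukin-15 (Mus musculus), read by resazurin assay, with stated times of 30 min and 2.5 days, in the presence of a further agent that is not named here (a higher number here means a weaker inhibitor, a lower number a stronger inhibitor), compound 1 reaches only the limit of the measurement, > 30000 nM. In this assay compound 2 gives a number, 23500 nM. The step of an at least 1.2-fold lower number from compound 1 to compound 2 (0.10 log units; that floor lies within the scatter) is therefore a floor rather than a measured distance, and it does not separate the two compounds.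

Compound 3, `Cn1c(Cc2nn(CCCO)c(=O)c3ccccc23)nnc1SCC(=O)Nc1ccc(Cl)cc1Cl`, carries the same side pieces on a different core; the difference between the two cores is not broken down here. In this assay compound 3 also gives only a limit, > 30000 nM. Compound 4, `Cn1c(Cc2nn(CCC(=O)O)c(=O)c3ccccc23)nnc1SCC(=O)Nc1ccc(Cl)cc1Cl`, stands to compound 3 as compound 2 stands to compound 1: carboxy in place of hydroxymethyl on a saturated chain carbon, two bonds along the chain from an aromatic nitrogen. This is the same change at the same place, made twice among these four compounds.

A step of about the same small size is expected here, an at least 1.1-fold lower number from compound 3 to compound 4 (0.04 log units; that floor lies within the scatter), because an at least 1.2-fold lower number from compound 1 to compound 2 (0.10 log units; that floor lies within the scatter) stayed within the scatter of repeated measurements. Since (the limit of > 30000 nM in this assay, at which 2 of the 3 values shown sit), the starting point is itself a limit, so any small gain leaves the new value close to that edge. Compound 4 is estimated at 27000 nM, with a likely range from 14000 nM to 60000 nM, and a fair chance that the measurement again reports only a limit.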

Compound 4, half-maximal inhibitory concentration: > 30000 nM
Compound 4 was reported as a limit (the forecaster's own chance of this, stated with the estimate: 55%); middle value at least 1.1-fold (0.04 log units) away from the limit.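

Compound 3 and compound 4 both end at a limit in this assay, so no step between them can be read, and the change from hydroxymethyl to carboxy gains no measured size on this core: the limit of > 30000 nM in this assay, at which 3 of the 4 values shown sit.

The compounds shown leave open how strong compound 1, compound 3 and compound 4 really are, and whether this same change acts alike on the two cores.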